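Two Inverted Stereocentres and Cell Tolerance

The compounds below may be only part of what the source reports. "The series", "measured", "known", "first", "only" and "open" are said of these compounds alone.

Before a compound goes further, chemists want to know how much of it cells can tolerate. In an ADME assay on Huh-7 cells (Homo sapiens) for cytotoxicity, read by thymidine incorporation (a lower number here means that less compound is tolerated, a higher number that more compound is tolerated), compound 1 `COC(=O)N[C@H](C(=O)N1CCC[C@H]1c1nc2ccc(-c3ccc(-c4ccc5nc([C@@H]6CCCN6C(=O)[C@@H](NC(=O)OC)C(C)C)[nH]c5c4)s3)cc2[nH]1)C(C)C` gives a half-maximal cytotoxic concentration of 6000 nM and compound 2 `COC(=O)N[C@H](C(=O)N1C[C@H](OC)C[C@H]1c1nc2cc(-c3ccc(-c4ccc5[nH]c([C@@H]6C[C@@H](OC)CN6C(=O)[C@@H](NC(=O)OC)C(C)C)nc5c4)cc3)ccc2[nH]1)C(C)C` gives 6000 nM on the same read-out. Among the compounds with values here, compound 2 therefore stands level with compound 1, and these two values are the only measurements so far.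

Compound 3 `COC(=O)N[C@H](C(=O)N1C[C@@H](OC)C[C@H]1c1nc2cc(-c3ccc(-c4ccc5[nH]c([C@@H]6C[C@H](OC)CN6C(=O)[C@@H](NC(=O)OC)C(C)C)nc5c4)cc3)ccc2[nH]1)C(C)C` is a stereoisomer of compound 2 (the two compounds have the same atoms and bonds and differ only in configuration as drawn: 2 of 6 stereo elements differ; a stereocentre at a saturated ring carbon is drawn R in compound 2 and S in compound 3; a stereocentre at a saturated ring carbon is drawn R in compound 2 and S in compound 3). A stereocentre is an atom whose three-dimensional arrangement is labelled R or S, so the same atoms and bonds can be drawn with different configurations.

Within the data shown here, no measured pair shows what this kind of change does on its own. The expectation therefore rests on compound 2 at 6000 nM and on the matching value of compound 1. I expect no step beyond the scatter in this assay and favour neither direction. The estimated shift is negligible (no change at the digits printed from compound 2 to compound 3 (within the scatter)). For compound 3 the estimated value is 6000 nM (expected range 2500 nM to 14000 nM).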

Compound 3, half-maximal cytotoxic concentration: > 20000 nM
Compound 3: a limit, no number; the forecaster's own chance of this, stated with the estimate: 25%; middle value at least 3.3-fold (0.52 log units) from the limit.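

Here the drawn configuration at two saturated ring carbons changes with no atom or bond altered, and this assay records an at least 3.3-fold higher number from compound 2 to compound 3 (0.52 log units; beyond the scatter). Compound 3 carries a limit of the assay and not a number: > 20000 nM. The earlier compounds shown here held no pair of this kind, and this step can be tied to configuration alone because nothing else separates the two structures: the fact that compounds 2 and 3 differ only in the configuration as drawn.

On these data alone, how large the step really is stays open, because compound 3 is read against a limit: the limit of > 20000 nM in this assay, at which 1 of the 3 values shown sits. Also open, as far as these compounds go, are whether inverting just one of the two ring carbons would give a step of its own, and whether an amine or a hydroxyl group in place of the methoxy group would respond to the same inversion in the same way.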